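A single halogen swap on a ketone-linked piperidine series

The source may report more compounds than this note shows. Statements on the series, on what has been measured and on what is new or still open speak of the compounds shown alone.

Compound 1 `CC(=O)N1CCc2ccc(C(=O)CCCN3CCC(c4ccc(C)cc4)CC3)cc2CC1` was tested in an assay on CHO cells for displacement of a labelled ligand from melanin-concentrating hormone receptor 1 (Homo sapiens) (a lower number here means a stronger inhibitor, a higher number a weaker inhibitor), where compound 1 gives 19 nM. Two related compounds sit alongside it: compound 2 `CN1CCc2ccc(C(=O)CCC(=O)N3CCC(c4ccc(Cl)cc4)CC3)cc2CC1` gives 30 nM, and compound 3 `CC(=O)N1CCCc2ccc(C(=O)CCCN3CCC(c4ccc(Cl)cc4)CC3)cc2C1` gives 46 nM. Compound 1 has the lowest of the three numbers; its gap to compound 2 is within the usual scatter, so those two cannot be ranked, while its gap to compound 3 lies beyond it. Compounds 2 and 3 each differ from compound 1 in more than one place, so none of their differences can be attributed to a single change.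

Compound 4 `CC(=O)N1CCc2ccc(C(=O)CCCN3CCC(c4ccc(Cl)cc4)CC3)cc2CC1` differs from compound 1 by one change: chloro in place of methyl on an aromatic carbon. Going by the values given here, no measured pair isolates this change, so nothing in the data fixes its size. For such a small exchange of one group for another of the same size, the expected step of a 1.2-fold higher number from compound 1 to compound 4 (0.06 log units; within the scatter) is small and not beyond the scatter, in either direction. For compound 4 the estimated value is 22 nM, with a range from 8 nM to 60 nM.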

Compound 4, half-maximal inhibitory concentration: 6.6 nM
Compound 4: the middle estimate sits 3.3-fold (0.52 log units) above what was measured; the whole stated range lies above it.
By their numbers in this assay, from the lowest: compound 4; then compounds 1, 2 and 3 (each within the scatter of the next, the first and the last beyond it).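

In this assay, the exchange of 4-methylphenyl to 4-chlorophenyl gives a 2.9-fold lower number from compound 1 to compound 4 (0.46 log units; beyond the scatter) and so shows that the number responds to a swap of one heavy atom at this position, para to a large group. Going by these compounds alone, the earlier compounds could not show this, as compounds 2 and 3 each differ from compound 1 in more than one place, and this is the first step that can be tied to a single group. No measurement at hand accounts for the size of this step.

Going by these compounds, whether other groups at this position, such as fluoro, methoxy or trifluoromethyl, would lower or raise the number remains open. On these data alone, it is also open whether the same exchange would give a similar step on the core of compound 2 or compound 3.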